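The compounds below may be only part of what the source reports. "The series", "measured", "known", "first", "only" and "open" are said of these compounds alone.

Compound 1 `COC1=C(O)[C@H](O)[C@H](C/C=C(\C)CC/C=C(\C)C[C@H](O)/C=C(\C)CO)[C@@H](C)C1=O` and compound 2 `COC1=C[C@H](O)[C@H](C/C=C(\C)CC/C=C(\C)C[C@H](O)/C=C(\C)CO)[C@@H](C)C1=O` share a long unsaturated side chain that ends in two hydroxy groups. In a functional assay on A549 cells (Homo sapiens) for inhibition, read by sulforhodamine B assay, with a stated time of 48 h (on this read-out higher numbers stand for weaker inhibition of growth and lower numbers for stronger inhibition of growth), compound 1 gives only a limit, > 30000 nM. In this assay compound 2 likewise gives only a limit, > 30000 nM. The step that the two limits leave unreadable from compound 1 to compound 2 is therefore not readable, since both ends rest on (the limit of > 30000 nM in this assay, at which 2 of the 3 values shown sit). Among the compounds with values here, compound 3 `COC1=C(OC)[C@H](OC(C)=O)[C@H](C/C=C(\C)CC/C=C(\C)C[C@H](O)C[C@@H](C)C(O)O)[C@@H](C)C1=O` carries an acetylated ring hydroxy and a chain that ends in a saturated hydrated aldehyde, and in this assay compound 3 gives 15400 nM, the only finite number among the three measured compounds.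

Compound 4 `COC1=C(OC)[C@H](OC(C)=O)[C@H](C/C=C(\C)CC/C=C(\C)C[C@H](O)/C=C(\C)C(=O)O)[C@@H](C)C1=O` differs from compound 3 by a group of 6 heavy atoms (4 carbon, 2 oxygen; no ring) in place of a group of 6 heavy atoms (4 carbon, 2 oxygen; no ring), on a saturated chain carbon bound to an oxygen on a saturated carbon and a saturated chain carbon. Within the data shown here, no measured step bears directly on this exchange: the one recorded step, between compound 1 and compound 2, touches the ring rather than the chain end and is itself unreadable. Without a comparable precedent, no step beyond the usual scatter is expected. In this assay compound 4 is therefore expected to give about 12000 nM, with a range from 3500 nM to 30000 nM. That estimate means a step of a 1.3-fold lower number from compound 3 to compound 4 (0.11 log units; within the scatter), expected to lie within the scatter of repeated measurements.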

Compound 4, concentration for 50% growth inhibition: > 30000 nM
Compound 4: a limit, no number (the forecaster's own chance of this, stated with the estimate: 35%); middle value at least 2.5-fold (0.39 log units) from the limit.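

Within the data shown here, at the saturated chain carbon bound to an oxygen on a saturated carbon and a saturated chain carbon, 2-carboxyprop-1-en-1-yl in place of the group carried by compound 3 gives the first step that has a readable floor: an at least 1.9-fold higher number from compound 3 to compound 4 (0.28 log units; that floor lies within the scatter) in this assay. The result for compound 4 is a limit and not a number, so the step has only this floor, and the floor alone does not carry the change beyond the scatter. What the exchange does show is that the finite reading of compound 3 is not kept once this one chain-end group is changed, which leaves compound 3 alone among the finite values: the limit of > 30000 nM in this assay, at which 3 of the 4 values shown sit.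

The compounds shown leave open how far the true value of compound 4 lies from its limit, and whether the double bond or the acid of the entering group matters more, since the two arrive together. Going by these compounds, it also remains open what a methyl ester or an amide at this chain end, in place of the carboxylic acid, would give in this assay.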